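Cyclopentyl to 4-fluorobenzyl on the amino nitrogen

The compounds below may be only part of what the source reports. "The series", "measured", "known", "first", "only" and "open" are said of these compounds alone.

Within the data shown here, compound 3 `CCOC(=O)c1cnc(NC2CCCC2)n2nc(-c3ccco3)nc12` gives 34.4 nM in an assay on CHO cells for displacement of a labelled ligand from adenosine receptor A1 (Homo sapiens) (a higher number here means a weaker inhibitor, a lower number a stronger inhibitor), the lowest of the numbers so far. Compound 1 `CNC(=O)c1cnc(NC(=O)NC2CCCCC2)n2nc(-c3ccco3)nc12` gives 8990 nM. Compound 2 `O=C(Nc1ncc(C(=O)O)c2nc(-c3ccco3)nn12)NC1CCCCC1` reaches only a limit of this assay, > 100000 nM; that is the limit of > 100000 nM in this assay, at which 1 of the 3 values shown sits. Among the measured compounds shown here, the one measured step, an at least 11-fold higher number from compound 1 to compound 2 (1.04 log units; beyond the scatter), concerns the carbonyl substituent, not the amino nitrogen, so it does not bear on the present change. Compound 4 `CCOC(=O)c1cnc(NCc2ccc(F)cc2)n2nc(-c3ccco3)nc12` differs from compound 3 by 4-fluorobenzyl in place of cyclopentyl on a nitrogen on an aromatic ring. For the measured compounds named here, no measured pair isolates a change on that nitrogen. Without a precedent, a modest move away from compound 3 is expected rather than a large one. Compound 4 is expected near 80 nM, between 15 nM and 400 nM. The estimate means an expected 2.3-fold higher number from compound 3 to compound 4 (0.37 log units; beyond the scatter).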

Compound 4, inhibition constant: 932 nM
Compound 4: middle estimate off by 12-fold (1.07 log units), on the low side; measured number above the stated range.
By their numbers in this assay, from the lowest: compound 3; then compound 4; then compound 1. At a limit, above all of these: compound 2.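

Among these compounds, replacing cyclopentyl with 4-fluorobenzyl on this nitrogen gives a 27-fold higher number from compound 3 to compound 4 (1.43 log units; beyond the scatter) in this assay and is the first measured evidence that this position is sensitive to the choice of group. Of the two groups, cyclopentyl gives the lower number. Nothing shown bears on why the step is so large.

Whether the aromatic ring or the fluorine accounts for the step remains open. Unsubstituted benzyl or cyclobutyl on the same nitrogen would begin to separate these, and the effect of an amine on this substituent is also unknown.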